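The compounds below may be only part of what the source reports. "The series", "measured", "known", "first", "only" and "open" are said of these compounds alone.

Measured compounds in a functional assay on PC-3 cells (Homo sapiens) for antiproliferative activity, read by MTT assay, with a stated time of 72 h; a lower number here means a stronger inhibitor, a higher number a weaker inhibitor:
compound 1 `C/C=C/C(=O)Nc1cc2c(N3CCc4ccccc43)ncnc2cc1OC` gives 8120 nM
compound 2 `COc1cc2ncnc(N3CCc4ccccc43)c2cc1NC(=O)/C=C/C(C)C` gives 6530 nM

Going by the values given here, of the two numbers, the one for compound 2 is the lower, but the step of a 1.2-fold lower number from compound 1 to compound 2 (0.09 log units; within the scatter) is within the scatter, so the two compounds cannot be told apart on these data. Among the compounds with values here, that single step, isopropyl in place of methyl on a double-bonded chain carbon bound to a double-bonded chain carbon, is the only measured step that touches the same place as the next change.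

Compound 3 `COc1cc2ncnc(N3CCc4ccccc43)c2cc1NC(=O)/C=C/CN1CCCCC1` has not yet been measured in this assay. It differs from compound 2 by (piperidin-1-yl)methyl in place of isopropyl on a double-bonded chain carbon bound to a double-bonded chain carbon. The group that enters is larger than the one it replaces and brings one six-membered non-aromatic ring with one hetero atom and one hydrogen-bond acceptor, whereas the measured step only exchanged one small carbon chain for another. Because that step a 1.2-fold lower number from compound 1 to compound 2 (0.09 log units; within the scatter) stayed within the scatter, the data give no firm direction for this much larger exchange, and a wide range is appropriate. The expectation for compound 3 is a modest move toward a lower number, a 1.9-fold lower number from compound 2 to compound 3 (0.27 log units; within the scatter), giving an estimated value of 3500 nM with a range from 1000 nM to 12000 nM.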

Compound 3, half-maximal inhibitory concentration: 4180 nM
Compound 3: the middle estimate sits 1.2-fold (0.08 log units) below what was measured, within the range that was stated.
By their numbers in this assay, from the lowest: compounds 3, 2 and 1 (each within the scatter of the next).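

In this assay the exchange gives a 1.6-fold lower number from compound 2 to compound 3 (0.19 log units; within the scatter) and so shows that this place on a double-bonded chain carbon can carry a larger group, with a six-membered non-aromatic ring and a nitrogen, without the number moving beyond the usual scatter. The comparison with the smallest chain, where piperidin-1-yl stands in place of hydrogen on a saturated chain carbon bound to a double-bonded chain carbon, gives a 1.9-fold lower number from compound 1 to compound 3 (0.29 log units; within the scatter) and also stays inside the scatter, so the methyl, isopropyl and (piperidin-1-yl)methyl versions cannot be told apart here. No supporting measurement is available that could explain this result.

Still open, going by these compounds, is whether any group at this place can shift the number beyond the scatter, for example a smaller amine such as dimethylamino, a morpholin-4-yl ring with its extra oxygen, or a carboxylic acid. Also open, on these data alone, is whether the shared core, rather than this chain, sets the level of the numbers, and only changes elsewhere on the core could answer that.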